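The source may report more compounds than this note shows. Statements on the series, on what has been measured and on what is new or still open speak of the compounds shown alone.

Measured so far:
compound 1 `Clc1ccc(/C=N/c2sc3c(c2-c2nc4ccccc4s2)CCC3)cc1` — 380 ug/mL
compound 2 `Fc1ccccc1/C=N/c1sc2c(c1-c1nc3ccccc3s1)CCC2` — 355 ug/mL

In an ADME assay on HeLa cells (Homo sapiens) for cytotoxicity, read by MTT assay, with a stated time of 72 h (a higher number here means that more compound is tolerated, a lower number that less compound is tolerated), compound 1 gives 380 ug/mL and compound 2 gives 355 ug/mL; the step of a 1.1-fold lower number from compound 1 to compound 2 (0.03 log units; within the scatter) lies within the scatter, so compound 2 stands within the scatter of compound 1 on the two numbers shown. Compound 3 `Clc1ccccc1/C=N/c1sc2c(c1-c1nc3ccccc3s1)CCC2` has not been measured in this assay. Its change from compound 2 is chloro in place of fluoro on an aromatic carbon. Among the measured compounds shown here, the only measured step that bears on it is the one from compound 1 to compound 2, which swaps the whole 4-chlorophenyl for 2-fluorophenyl and gives a 1.1-fold lower number from compound 1 to compound 2 (0.03 log units; within the scatter), a change within the scatter; the present change is a smaller one, a single halogen swap on the same aromatic ring. No step beyond the scatter is therefore expected in this assay for compound 3, the estimated step being a 1.0-fold higher number from compound 2 to compound 3 (0.01 log units; within the scatter). Compound 3 is expected at 360 ug/mL, with a range of 240 ug/mL to 540 ug/mL.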

Compound 3, half-maximal cytotoxic concentration: 138 ug/mL
Compound 3: middle estimate off by 2.6-fold (0.42 log units), on the high side; the whole stated range lies above it.
By their numbers in this assay, from the lowest: compound 3; then compounds 2 and 1 (each within the scatter of the next).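

In this assay, the ring position ortho to a large group responds to the identity of the halogen, which the earlier pair did not reveal: the swap of fluoro for chloro gives a 2.6-fold lower number from compound 2 to compound 3 (0.41 log units; beyond the scatter). Moving chloro within the ring to that place gives a similar result, with a 2.8-fold lower number from compound 1 to compound 3 (0.44 log units; beyond the scatter), so among these compounds less is tolerated only with 2-chlorophenyl, whereas 2-fluorophenyl and 4-chlorophenyl remain within the scatter of each other. Nothing available here accounts for this difference between the halogens.

Open, on these data alone, is whether the lower number extends to other groups at this place, such as bromo, methyl, methoxy or an amine. Also open, as far as these compounds go, is whether 3-chlorophenyl would sit with compound 3 or with compound 1 and compound 2.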